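Amine nitrogen substituent change from compound 1 to compound 3

The source may report more compounds than this note shows. Statements on the series, on what has been measured and on what is new or still open speak of the compounds shown alone.

Measured so far:
compound 1 `CCCn1c(=O)[nH]c2nc(-c3ccc(S(=O)(=O)N4CCN(Cc5cccc(C)c5)CC4)cc3)[nH]c2c1=O` — 17%
compound 2 `CCCn1c(=O)[nH]c2nc(-c3ccc(S(=O)(=O)N4CCN(c5ccccc5F)CC4)cc3)[nH]c2c1=O` — 9%

In an assay on CHO cells for displacement of a labelled ligand from adenosine receptor A3 (Homo sapiens), read by scintillation counting, with a stated time of 45 min, tested at 1 uM, in the presence of a further agent that is not named here (a lower number here means less inhibition, a higher number more inhibition at the concentration tested (going by the name of the read-out)), compound 1 gives 17%, the higher of the two numbers; compound 2 gives 9%, and the step of a number 8 percentage points lower from compound 1 to compound 2 (within the scatter) lies within the scatter. Compound 3 `CCCn1c(=O)[nH]c2nc(-c3ccc(S(=O)(=O)N4CCN(c5ccc(C)cc5)CC4)cc3)[nH]c2c1=O` is not yet measured. The change: 4-methylphenyl in place of 3-methylbenzyl on an amine nitrogen in a ring. Among the compounds with values here, the only measured step that bears on it, a number 8 percentage points lower from compound 1 to compound 2 (within the scatter), also replaces 3-methylbenzyl on the same amine nitrogen in a ring and stayed within the scatter, so no step beyond the scatter is expected in this assay. Compound 3 is therefore expected at 12%, between 0% and 28%. The expected step is a number 5 percentage points lower from compound 1 to compound 3 (within the scatter).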

Compound 3, a percentage reported as inhibition, at one concentration (the size of the read-out at that concentration, not a potency): 25%
Beside the measured number, compound 3's estimate is 13 percentage points below it, within the range that was stated.
By their numbers in this assay, from the lowest: compounds 2, 1 and 3 (each within the scatter of the next, the first and the last beyond it).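

Within the data shown here, on the amine nitrogen in a ring, in this assay, 4-methylphenyl in place of 3-methylbenzyl gives a number 8 percentage points higher from compound 1 to compound 3 (within the scatter), so this exchange is not resolved from the scatter. 4-methylphenyl in place of 2-fluorophenyl gives a number 16 percentage points higher from compound 2 to compound 3 (beyond the scatter), the first step at this position beyond the scatter, and it separates two aryl groups placed directly on that nitrogen. Nothing available accounts for this difference.

Open, on these data alone, is where unsubstituted phenyl on the same nitrogen would fall relative to compound 2 and compound 3. Also open, as far as these compounds go, is how a longer chain such as 2-phenylethyl would read here.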